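The source may hold more compounds than are shown below. What is called first, only, known or untested is meant among the compounds shown, and "the series" means these compounds.

Among the compounds with values here, compound 1 `CC(C)=CCC[C@]1(C)/C=C/[C@@H](OC(=O)C=C(C)C)[C@](C)(O)/C=C/C(=O)/C(CN(C)C)=C\C1` carries the only number in this set: in a functional assay on SW480 cells (Homo sapiens) for antiproliferative activity, read by MTT assay, with a stated time of 48 h (a lower number here means a stronger inhibitor, a higher number a weaker inhibitor), compound 1 gives 480 nM. Compound 2 `CC(C)=CCC[C@]1(C)/C=C/[C@@H](OC(=O)C=C(C)C)[C@](C)(O)/C=C/[C@H](O)/C(CO)=C\C1` reaches only a limit in this assay, > 40000 nM, which is the limit of > 40000 nM in this assay, at which 1 of the 2 values shown sits. Compound 3 `CC(C)=CCC[C@]1(C)/C=C/[C@@H](OC(=O)C=C(C)C)[C@](C)(O)/C=C/C(=O)/C(C(=O)N(C)C)=C\C1` has not yet been measured; it differs from compound 1 by dimethylcarbamoyl in place of (dimethylamino)methyl on a double-bonded ring carbon. Within the data shown here, no step between two measured compounds is available to guide this change, so the step of a 5.2-fold higher number from compound 1 to compound 3 (0.72 log units; beyond the scatter) is an expectation of a loss beyond the usual scatter. Compound 3 is accordingly expected at 2500 nM, with a range from 600 nM to 12000 nM.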

Compound 3, half-maximal inhibitory concentration: 3300 nM
For compound 3 the middle estimate is 1.3-fold (0.12 log units) below the measured one; low and high end bracket the measured number.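

In this assay, this double-bonded ring carbon proves sensitive to the group it carries: placing dimethylcarbamoyl where (dimethylamino)methyl stood gives a 6.9-fold higher number from compound 1 to compound 3 (0.84 log units; beyond the scatter). Compound 3 nevertheless gives a number, 3300 nM, not a limit, so activity survives this change. Nothing measured here gives a reason for the loss. The compounds shown leave open how a primary amine, a morpholine or a carboxylic acid would read at this ring carbon. They also leave open the effect of a longer chain carrying the dimethylamino group.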